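Turning One Double Bond from Z to E

The source may hold more compounds than are shown below. What is called first, only, known or untested is meant among the compounds shown, and "the series" means these compounds.

In a functional assay on DU-145 cells (Homo sapiens) for antiproliferative activity, read by WST assay, with a stated time of 72 h (on this read-out lower numbers stand for an effect already at smaller amounts and higher numbers for an effect only at larger amounts of compound), compound 1 `CCCCCCCC/C=C\c1c(C)nc(C)c(/C=C\CCCCCCCC)c1C` reached only a limit, > 30 uM. Among the compounds with values here, compound 2 `CCCCCCCC/C=C\c1c(C)c(/C=C\CCCCCCCC)c2[n+](c1C)CCC2` gives 1 uM, which makes it the only compound in this small set with an actual number and the sole reference point for what follows. Its unmeasured partner is compound 3 `CCCCCCCC/C=C\c1c(C)c(/C=C/CCCCCCCC)c2[n+](c1C)CCC2`. The difference between the two is small: the two compounds have the same atoms and bonds and differ only in configuration as drawn: 1 of 2 stereo elements differ; a double bond is drawn Z in compound 2 and E in compound 3. They have the same atoms and bonds, and a double bond is drawn Z in compound 2 and E in compound 3.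

Within the data shown here, no measured pair here shows what such a change does to the read-out, so any expectation is necessarily tentative. It rests on compound 2 at 1 uM and on how little the structure changes. In this assay, no step beyond the usual scatter is expected, with only a slight lean towards a higher number. The estimated change is a 1.4-fold higher number from compound 2 to compound 3 (0.15 log units; within the scatter). Compound 3 is expected at 1.4 uM, with an estimated range from 0.5 uM to 4 uM.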

Compound 3, concentration for half-maximal effect: 0.2 uM
For compound 3 the middle estimate is 7.0-fold (0.85 log units) above the measured one; measured number below the stated range.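

In this assay the read-out responds to the configuration of a single double bond, with a 5.0-fold lower number from compound 2 to compound 3 (0.70 log units; beyond the scatter). Within the data shown here, this is the first step that can be read in the set, and it shows that this double bond is not a neutral part of the structure: drawing it E rather than Z gives a lower number, beyond the usual scatter, with no other part of the compound altered. Compound 1 and compound 2 differ in more than one place and offered no such reading, whereas here the step belongs to that one double bond alone: the fact that compounds 2 and 3 differ only in the configuration as drawn

What the compounds shown leave open is whether the other double bond, still drawn Z in compound 3, would respond in the same way if drawn E, and whether the two changes together would move the number further. Also open, as far as these compounds go, is how far this single pair extends to other compounds, for instance whether the same change in configuration would give a similar step with a longer chain or with a carboxylic acid carried on the chain.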